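Resorcinol isoxazole amides: pyrazole replacement at the aryl position

The source may hold more compounds than are shown below. What is called first, only, known or untested is meant among the compounds shown, and "the series" means these compounds.

Measured so far:
compound 1 `CCNC(=O)c1noc(-c2cc(C(C)C)c(O)cc2O)c1-c1cc(CNC)no1` — "not determined" (no result reported)
compound 2 `CCNC(=O)c1cc(-c2c(C(=O)NCC)noc2-c2cc(C(C)C)c(O)cc2O)on1` — 43 nM

In a functional assay on A2780 cells (Homo sapiens) for inhibition (a lower number here means a stronger inhibitor, a higher number a weaker inhibitor), compound 1 is recorded as "not determined" (no result reported); only compound 2 anchors the series. In this assay compound 2 gives 43 nM, which is the sole measured point and the only reference against which a new analogue can be placed.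

Compound 3 `CCNC(=O)c1noc(-c2cc(C(C)C)c(O)cc2O)c1-c1cnn(C)c1` derives from compound 1 by a single exchange of the five-membered substituent on the shared core: 1-methyl-1H-pyrazol-4-yl in place of 3-((methylamino)methyl)-1,2-oxazol-5-yl on an aromatic carbon. Within the data shown here, with no number for compound 1 and no step between measured compounds, the size of this move in this assay cannot be read from the series itself. The expectation is a step no larger than the usual scatter, in no definite direction, with compound 3 landing close to where compound 2 stands, since compound 2 shows 43 nM on the same core with a related five-membered group in that place.

Compound 3 is therefore estimated at 60 nM in this assay, with a plausible range from 15 nM to 250 nM.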

Compound 3, half-maximal inhibitory concentration: 20 nM
Estimate against measurement, compound 3: 3.0-fold (0.48 log units) above, and the stated range covers the measured number.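

In this assay, among these compounds, 1-methyl-1H-pyrazol-4-yl in place of 3-(ethylcarbamoyl)-1,2-oxazol-5-yl on this aromatic carbon gives a 2.2-fold lower number from compound 2 to compound 3 (0.33 log units; beyond the scatter), the first step that can be read at this position. The step is modest but beyond the scatter, so the number responds to the five-membered group carried here, and the ethylcarbamoyl group is not needed for activity: without it, compound 3 gives 20 nM. Nothing in hand accounts for the size or direction of this step.

Among the compounds shown here, compound 1 has no number, so no step involving it can be read, and the effect of 3-((methylamino)methyl)-1,2-oxazol-5-yl at this position in this assay stays unknown. Also open, on these data alone, is how a longer chain such as 2-hydroxyethyl, or a carboxylic acid, in place of the methyl of 1-methyl-1H-pyrazol-4-yl would compare with compound 3.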